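Bromine for Methyl on the Aryl Ether: Cytotoxicity Outlook

The compounds below may be only part of what the source reports. "The series", "measured", "known", "first", "only" and "open" are said of these compounds alone.

Compound 1, `N#Cc1ccc(Nc2nc(Oc3c(Br)cc(Br)cc3Br)c3ccccc3n2)cc1`, in an ADME assay on MT4 cells (Homo sapiens) for cytotoxicity, read by MTT assay, with a stated time of 4 days (on this read-out lower numbers stand for higher toxicity in this test and higher numbers for lower toxicity in this test), gives 58000 nM.
Compound 2, `Cc1cc(C)c(Oc2nc(Nc3ccc(C#N)cc3)nc3ccccc23)c(C)c1`, in this assay gives only a limit, > 34000 nM.
Compound 3, `Cc1cc(C#N)cc(C)c1Oc1nc(Nc2ccc(C#N)cc2)nc2ccc(Cl)cc12`, in this assay gives 117000 nM.

Compound 2 stands at a limit of this assay and has no number of its own. Among the compounds with values here, for that reason the step from compound 1 to compound 2, a step that the limit leaves unreadable from compound 1 to compound 2, cannot be read in size; the only evidence on it is the limit itself, (the limit of > 34000 nM in this assay, at which 1 of the 3 values shown sits). Compound 4, `Cc1cc(Br)cc(Br)c1Oc1nc(Nc2ccc(C#N)cc2)nc2ccccc12`, differs from compound 2 by 2,4-dibromo-6-methylphenyl in place of 2,4,6-trimethylphenyl on an oxygen on an aromatic ring. Within the data shown here, no measured step bears directly on this change, so the expectation rests on compound 1, whose tribromo ring gives 58000 nM. It rests also on where compound 2 sits, which is a limit of this assay. Compound 4 carries two of the three bromines of compound 1 and one methyl of compound 2, so its cytotoxic concentration is expected to fall near that of compound 1 and within the scatter of it. The expected step from compound 2 to compound 4 is a step that the limit leaves unreadable from compound 2 to compound 4, a step that may well stay hidden by the limit. Compound 4 is therefore estimated at 55000 nM, from 25000 nM to 130000 nM.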

Compound 4, half-maximal cytotoxic concentration: 150000 nM
Compound 4: middle estimate off by 2.7-fold (0.44 log units), on the low side, and the stated range ends below it.
By their numbers in this assay, from the lowest: compounds 1, 3 and 4 (each within the scatter of the next, the first and the last beyond it).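

Within the data shown here, until this result, no change on the aromatic ring on the oxygen could be read in size. Methyl in place of bromo on an aromatic carbon now gives a 2.6-fold higher number from compound 1 to compound 4 (0.41 log units; beyond the scatter) in this assay, so this single change moves the number in the direction of lower toxicity in this test. The steps that involve compound 2 still cannot be read, because compound 2 has only a limit and no number of its own: the limit of > 34000 nM in this assay, at which 1 of the 4 values shown sits.

Going by these compounds, how much of the change from compound 1 to compound 4 would carry over to further replacement of bromo by methyl stays open. Also open, on these data alone, is what a methoxy group, an amine or a carboxylic acid on that same aromatic carbon would do to the number in this assay.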